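The compounds below may be only part of what the source reports. "The series", "measured", "known", "first", "only" and "open" are said of these compounds alone.

Compound 2 `C#CCn1c(-c2ccc(C(=O)N/N=C/c3ccccc3OC)cc2)nc2ccccc21` belongs to a small set of analogues sharing one core, all tested in an assay on cells for inhibition of Amine oxidase [flavin-containing] A (Homo sapiens), read by fluorescence and Amplex Red, with stated times of 30 min and 5 min; a higher number here means a weaker inhibitor, a lower number a stronger inhibitor. In this assay compound 2 gives only a limit, >= 1000000 nM, not a number. Its neighbour compound 1 `C#CCn1c(-c2ccc(C(=O)N/N=C/c3ccc(Cl)cc3)cc2)nc2ccccc21` also gives only a limit in this assay, namely >= 100000 nM. The step that the two limits leave unreadable from compound 1 to compound 2 therefore has no readable size; the two lines the limit of >= 100000 nM in this assay, at which 1 of the 2 values shown sits, and the limit of >= 1000000 nM in this assay, at which 1 of the 2 values shown sits, simply mark where the two values sit. Compound 3 `C#CCn1c(-c2ccc(C(=O)N/N=C/c3cccc(O)c3)cc2)nc2ccccc21` differs from compound 2 in one place: 3-hydroxyphenyl in place of 2-methoxyphenyl on a carbon with a double bond to nitrogen. Among the compounds with values here, no measured step bears directly on this change, and the only step in the set is unreadable, so no shift beyond the usual scatter can be argued in either direction. The estimate for compound 3 in this assay is accordingly 300000 nM, within 30000 nM to 3000000 nM, which corresponds to an expected step of an at least 3.3-fold lower number from compound 2 to compound 3 (0.52 log units; beyond the scatter).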

Compound 3, half-maximal inhibitory concentration: >= 1000000 nM
Compound 3: a limit, no number (the forecaster's own chance of this, stated with the estimate: 70%); middle value at least 3.3-fold (0.52 log units) from the limit.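

In this assay, within the data shown here, compound 1, compound 2 and compound 3 all give only limits, not numbers, so no step among them can be read. From the compounds shown here alone, what stays open is the actual value of each compound and whether exchanging these groups changes inhibition at all.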